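The source may hold more compounds than are shown below. What is called first, only, known or untested is meant among the compounds shown, and "the series" means these compounds.

In a functional assay on Ehrlich cells (Mus musculus) for cytotoxicity, read by trypan blue exclusion, with a stated time of 48 h (on this read-out lower numbers stand for stronger inhibition and higher numbers for weaker inhibition), compound 2 `Cc1cc(C(=O)c2ccc(F)cc2)ccc1OCC(=O)Nc1nc(-c2ccccc2)cs1` gives 35200 nM, the highest number among the three measured compounds. Compound 1 `Cc1cc(C(=O)c2ccccc2)ccc1OCC(=O)Nc1nc(-c2ccccc2)cs1` gives 22300 nM, and the step of a 1.6-fold higher number from compound 1 to compound 2 (0.20 log units; within the scatter) stays within the scatter. Compound 3 `COc1ccc(-c2csc(NC(=O)COc3ccc(C(=O)c4ccc(F)cc4)cc3C)n2)cc1` gives 5200 nM, and the step of a 6.8-fold lower number from compound 2 to compound 3 (0.83 log units; beyond the scatter) lies beyond it. Compound 4 `Cc1cc(C(=O)c2ccccc2F)ccc1OCC(=O)Nc1nc(-c2ccccc2)cs1` has not yet been measured. It differs from compound 2 by 2-fluorophenyl in place of 4-fluorophenyl on a carbonyl carbon. Going by the values given here, of the measured steps, only the step from compound 1 to compound 2 touches this part of the structure, and that step was within the scatter, so no change beyond the scatter is expected in this assay from moving the fluorine. For compound 4, the expected value is 30000 nM, with a range from 10000 nM to 90000 nM, which amounts to an estimated step of a 1.2-fold lower number from compound 2 to compound 4 (0.07 log units; within the scatter).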

Compound 4, half-maximal inhibitory concentration: 15400 nM
Compound 4: middle estimate off by 1.9-fold (0.29 log units), on the high side; the measured number falls inside the stated range.
By their numbers in this assay, from the lowest: compound 3; then compounds 4, 1 and 2 (each within the scatter of the next, the first and the last beyond it).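

this assay Moving the fluorine, with the same atoms kept, gives a 2.3-fold lower number from compound 2 to compound 4 (0.36 log units; beyond the scatter) for 2-fluorophenyl in place of 4-fluorophenyl on the carbonyl carbon, so where the fluorine sits on this ring can matter. Yet fluoro in place of hydrogen gives a 1.4-fold lower number from compound 1 to compound 4 (0.16 log units; within the scatter) here, so 2-fluorophenyl stands apart from 4-fluorophenyl but not from the unsubstituted ring. No evidence is at hand on the reason for this difference. Open, on these data alone, is how a chlorine or an amine in place of the fluorine would read, and whether the shift from moving the fluorine persists alongside the methoxy group of compound 3.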